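Chloro for methoxy on the aryl arm of compound 1

A few compounds are considered here, and "the series" means these few. Any claim that something is new, unique, unknown or untested is made for them only; others in the source may bear on it.

Among the compounds with values here, compound 1 `COc1ccc(-c2cs/c(=N\NC(=O)c3ccc(O)cc3)n2-c2ccc(OC)cc2OC)cc1` is the only compound of this pair with a number in a functional assay on HCT-116 cells (Homo sapiens) for cytotoxicity, read by sulforhodamine B assay, with a stated time of 48 h; on this read-out lower numbers stand for stronger inhibition of growth and higher numbers for weaker inhibition of growth; compound 1 gives 28200 nM there. Compound 2 `Cc1ccc(-c2cs/c(=N\NC(=O)c3ccc(O)cc3)n2-c2c(C)cccc2C)cc1` gives < 100000 nM in this assay, a limit rather than a number, namely (the limit of < 100000 nM in this assay, at which 1 of the 2 values shown sits). Compound 3 `COc1ccc(-n2c(-c3ccc(Cl)cc3)cs/c2=N\NC(=O)c2ccc(O)cc2)c(OC)c1` has not been measured; it differs from compound 1 by chloro in place of methoxy on an aromatic carbon. Within the data shown here, no measured pair shows this exchange, so the step of a 1.1-fold lower number from compound 1 to compound 3 (0.05 log units; within the scatter) is expected to remain within the usual scatter, with no clear direction. Compound 3 is accordingly estimated at 25000 nM, within 8000 nM to 80000 nM.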

Compound 3, concentration for total growth inhibition: < 100000 nM
Compound 3: only a limit was reported (the forecaster's own chance of this, stated with the estimate: 15%); the middle value does not contradict the limit.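

No step can be read from compound 1 to compound 3 in this assay, because compound 3 carries only a limit there: the limit of < 100000 nM in this assay, at which 2 of the 3 values shown sit.

The compounds shown leave open whether going from 4-methoxyphenyl to 4-chlorophenyl changes growth inhibition at all, and in which direction.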